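Adding a Chloro Group: From Compound 3 to Compound 4

A few compounds are considered here, and "the series" means these few. Any claim that something is new, unique, unknown or untested is made for them only; others in the source may bear on it.

Three compounds built on a shared core were examined in an assay on CHO cells for displacement of a labelled ligand from adenosine receptor A3 (Homo sapiens), read by scintillation counting, tested at 10 uM; on this read-out higher numbers stand for more inhibition at the one concentration tested (going by the name of the read-out) and lower numbers for less inhibition. Compound 1 `CC(C)(C)Cc1c(-c2ccoc2)sc(N)c1C(=O)c1ccc(Cl)cc1` gives 1%. Compound 2 `CC(C)(C)Cc1c(-c2ccc(Cl)cc2)sc(N)c1C(=O)c1ccc(Cl)cc1` gives 1%, and compound 3 `CC(C)(C)Cc1c(Br)sc(N)c1C(=O)c1ccc(Cl)cc1` gives 1%. Compound 3 thus stands level with both of its neighbours: no change at the digits printed from compound 1 to compound 3 (within the scatter) and no change at the digits printed from compound 2 to compound 3 (within the scatter), while between the other pair no change at the digits printed from compound 1 to compound 2 (within the scatter). Compound 4 `CC(C)(C)Cc1c(Br)sc(N)c1C(=O)c1ccc(Cl)c(Cl)c1` differs from compound 3 in one place: chloro in place of hydrogen on an aromatic carbon. For the measured compounds named here, none of the measured steps touches this ring; all three instead exchange the group on an aromatic carbon of the core, and every one of them stayed within the scatter. Going by the values given here, no measured step therefore bears directly on the change, and all three measured values show essentially no inhibition at the single concentration. Compound 4 is accordingly expected to stay at the same level, with an estimated step of a number 2 percentage points higher from compound 3 to compound 4 (within the scatter). The estimate for compound 4 in this assay is 3%, ranging from -5% to 15%.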

Compound 4, a percentage reported as inhibition, at one concentration (the size of the read-out at that concentration, not a potency): 1%
For compound 4 the middle estimate is 2 percentage points above the measured one, and the stated range covers the measured number.
By their numbers in this assay, from the lowest: compounds 1, 2, 3 and 4 (each within the scatter of the next).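

For the compounds shown here, this is the first step to touch the ring carrying the chloro group, rather than the group on the core: in this assay a second chloro group, ortho to the first and meta to a large group, gives no change at the digits printed from compound 3 to compound 4 (within the scatter). Changes at this second position have thus joined those on the core in leaving the read-out where it was, so that all four compounds sit level at essentially no inhibition. Nothing on hand offers an explanation for this result.

Going by these compounds, what a methoxy group, an amine or a carboxylic acid would do at this same place on the ring remains open. So does whether this chloro group would have any effect with furan-3-yl or 4-chlorophenyl on the core in place of bromo.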